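Trimethoxyphenyl series: a second fluoro on compound 1

The compounds below may be only part of what the source reports. "The series", "measured", "known", "first", "only" and "open" are said of these compounds alone.

Measured so far, in a functional assay on PC-3 cells (Homo sapiens) for antiproliferative activity, read by MTT assay, tested at 5 uM; on this read-out higher numbers stand for a stronger effect at the one concentration tested and lower numbers for a weaker effect:
- compound 1 `COc1cc(C2=NN(C(C)=O)C(c3cccc(F)c3)O2)cc(OC)c1OC` gives 43.5%
- compound 2 `COc1ccc(OC)c(/C=N/NC(=O)c2cc(OC)c(OC)c(OC)c2)c1` gives 51.7%
- compound 3 `COc1ccc(/C=N/NC(=O)c2cc(OC)c(OC)c(OC)c2)c(OC)c1` gives 22.2%

Compound 1 stands second highest of the three numbers. Its nearest neighbour is compound 2, whose number is higher but within the scatter, so the two cannot be ordered. Going by the values given here, compound 3 sits furthest away, with a number lower by more than the scatter; of that pair only the two values themselves are known, as no step between them is recorded.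

Compound 4 `COc1cc(C2=NN(C(C)=O)C(c3ccc(F)c(F)c3)O2)cc(OC)c1OC` is the next compound in this assay. Its change from compound 1 is fluoro in place of hydrogen on an aromatic carbon, on the aromatic carbon ortho to the fluoro group already present. Among the compounds with values here, no measured pair in the set isolates such a change, so there is no step to lean on. Given that, the step from compound 1 to compound 4 is expected to be small, most likely none beyond the scatter, with a slight lean towards a higher number: a number 3.5 percentage points higher from compound 1 to compound 4 (within the scatter). Compound 4 is therefore estimated at 47%, within a range of 30% to 64%.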

Compound 4, a percentage reported as inhibition, at one concentration (the size of the read-out at that concentration, not a potency): 46.9%
Beside the measured number, compound 4's estimate is 0.1 percentage points above it; measured number inside the range.
By their numbers in this assay, from the lowest: compound 3; then compounds 1, 4 and 2 (each within the scatter of the next).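

In this assay, the change from 3-fluorophenyl to 3,4-difluorophenyl gives a number 3.4 percentage points higher from compound 1 to compound 4 (within the scatter), the first single-place step available in this series. At this position, ortho to a fluoro group and para to a large group, fluoro in place of hydrogen therefore leaves the read-out within the scatter, so compound 1 and compound 4 cannot be ordered. No supporting data are available to interpret this result.

The compounds shown carry only hydrogen or fluoro at this position, so the outcome with a larger or differently charged group there, such as a methoxy group, an amine or a carboxylic acid, remains open. From the compounds shown here alone, with a single tested concentration, it also remains open whether compound 1 and compound 4 would differ in potency.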